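The source may hold more compounds than are shown below. What is called first, only, known or untested is meant among the compounds shown, and "the series" means these compounds.

Going by the values given here, in a physicochemical assay for lipophilicity, at pH 7.4 (a higher number here means a more lipophilic compound, a lower number a more polar compound), compound 2 (`CNC(=O)c1cc(C(N)=O)cc2c1O[C@H](CF)[C@H]2c1ccccc1`) gives 2.9, within the scatter of compound 1 (`CNC(=O)c1cc(C(N)=O)cc2c1OC[C@H]2c1ccccc1`) at 2.7; compound 3 (`CNC(=O)c1cc(C(=O)N[C@H]2[C@@H]3COC[C@@H]32)cc2c1OC[C@H]2C1CCOCC1`) gives 2.1, and that number stands lower than the one of compound 2, beyond the scatter. Compound 4 (`CNC(=O)c1cc(C(=O)NC2CC2)cc2c1O[C@H](CF)[C@H]2c1ccccc1`) differs from compound 2 in one place: cyclopropyl in place of hydrogen on an amide-type nitrogen. Among the compounds with values here, the only measured step, a number 0.20 log units higher from compound 1 to compound 2 (within the scatter), is within the scatter and concerns fluoromethyl on a saturated ring carbon, so it gives no direct size for this change. Compound 3 differs from compound 2 in more than one place and isolates nothing. A moderate rise is expected, resting on the structural change alone. The expected step is a number 0.40 log units higher from compound 2 to compound 4 (beyond the scatter). For compound 4 the estimated value is 3.3, with an expected range from 2.9 to 3.7.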

Compound 4, distribution coefficient: 3.9
For compound 4 the middle estimate is 0.60 log units below the measured one; measured number outside the range, above it.
By their numbers in this assay, from the lowest: compound 3; then compounds 1 and 2 (each within the scatter of the next); then compound 4.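

On the amide-type nitrogen, cyclopropyl in place of hydrogen gives a step in this assay that lies beyond the scatter (a number 1.00 log units higher from compound 2 to compound 4 (beyond the scatter)). The fluoromethyl change on a saturated ring carbon stayed within the scatter (a number 0.20 log units higher from compound 1 to compound 2 (within the scatter)), so this nitrogen is the only place shown where a single change clearly moves the number. Nothing measured here accounts for the size of this step.

As far as these compounds go, whether an ethyl group, a longer chain or a chain ending in an amine on this nitrogen gives a similar step remains open. Also open, from the compounds shown here alone, is whether cyclopropyl gives the same step on the core of compound 1.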